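Replacing pyridin-3-yl with 1H-indol-3-yl in compound 3

A few compounds are considered here, and "the series" means these few. Any claim that something is new, unique, unknown or untested is made for them only; others in the source may bear on it.

Within the data shown here, in a functional assay (strain AB) with Danio rerio as the target, read by microscopy, with a stated time of 1 h (a lower number here means that less compound is needed, a higher number that more compound is needed for the effect), compound 2 `NC(=O)c1c(NC(=O)Nc2ccc(Cl)cc2)sc2c1CCN(CCCNC(=O)CCc1cccnc1)C2` gives 470 nM, the higher of the two numbers measured so far. Among the measured compounds shown here, its only comparison is compound 1 `NC(=O)c1c(NC(=O)Nc2ccc(Cl)cc2)sc2c1CCN(CCCNC(=O)CCc1cccc3ccccc13)C2`, which gives 110 nM. The two differ in one place, on a saturated chain carbon, two bonds along the chain from a carbonyl carbon, where pyridin-3-yl stands in place of naphthalen-1-yl.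

Compound 3 `NC(=O)c1c(NC(=O)Nc2ccc(Cl)cc2)sc2c1CCN(CCCNC(=O)CCc1c[nH]c3ccccc13)C2` changes that same place again: 1H-indol-3-yl in place of pyridin-3-yl on a saturated chain carbon, two bonds along the chain from a carbonyl carbon. In words, 1H-indol-3-yl replaces pyridin-3-yl, while the rest of the structure stays the same. For the measured compounds named here, only one measured step bears on this change: a 4.3-fold higher number from compound 1 to compound 2 (0.63 log units; beyond the scatter). Going by the values given here, that modest step lies beyond the scatter, but it is a single pair, and the data hold no measured compound with 1H-indol-3-yl at this place. Since the entering group, like naphthalen-1-yl, carries a six-membered aromatic ring of carbon only, a partial return toward compound 1 seems the likeliest outcome. The expected change is a lower number, estimated as a 2.8-fold lower number from compound 2 to compound 3 (0.44 log units; beyond the scatter). For compound 3 the estimated value is 170 nM, with an expected range of 70 nM to 420 nM.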

Compound 3, half-maximal effective concentration: 100 nM
Beside the measured number, compound 3's estimate is 1.7-fold (0.23 log units) above it; low and high end bracket the measured number.
By their numbers in this assay, from the lowest: compounds 3 and 1 (each within the scatter of the next); then compound 2.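

In this assay, this position proves able to take a group other than naphthalen-1-yl without a measurable loss, since 1H-indol-3-yl gives a 4.7-fold lower number from compound 2 to compound 3 (0.67 log units; beyond the scatter), while the comparison with the naphthalene compound gives a 1.1-fold lower number from compound 1 to compound 3 (0.04 log units; within the scatter). The earlier pair alone could be read as saying that a ring nitrogen in this group goes with a higher number, but compound 3 goes against that reading: its 1H-indol-3-yl group carries a ring nitrogen and a hydrogen-bond donor, and its value still lies within the scatter of that of compound 1, so among these three compounds only compound 2, with pyridin-3-yl, stands apart. Nothing in the available evidence explains why pyridin-3-yl differs from the other two groups.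

The compounds shown leave open whether the amide-linked chain needs a fused ring system at this place at all, which a plain phenyl group in the same place would test, and whether a pyridine ring fused to a benzene ring, as in quinolin-3-yl, would behave like pyridin-3-yl or like 1H-indol-3-yl. They also leave open what the indole hydrogen contributes, which 1-methyl-1H-indol-3-yl would address.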